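The source may hold more compounds than are shown below. What is called first, only, known or untested is meant among the compounds shown, and "the series" means these compounds.

Of the compounds shown here, three of a shared core have been measured in an assay on CHO cells for binding affinity to metabotropic glutamate receptor 2 (Rattus norvegicus); a lower number here means a stronger inhibitor, a higher number a weaker inhibitor. Compound 1 `CCC(C)O[C@@H]1C[C@@H]2[C@H]([C@]1(N)C(=O)O)[C@@]2(F)C(=O)O` gives 6.68 nM. Compound 2 `N[C@]1(C(=O)O)[C@H]2[C@@H](C[C@H]1OCc1cccc(Cl)c1)[C@]2(F)C(=O)O` gives 3.28 nM, the lowest of the three numbers, which means the strongest binding seen so far. Compound 3 `N[C@]1(C(=O)O)[C@H]2[C@@H](C[C@H]1OCc1cccc(Oc3ccccc3)c1)[C@]2(F)C(=O)O` gives 7.15 nM. Among the compounds with values here, the only single-change step between measured compounds is the one from compound 2 to compound 3, where a phenoxy group replaces the chloro group on an aromatic carbon: it gives a 2.2-fold higher number from compound 2 to compound 3 (0.34 log units; beyond the scatter), a modest weakening.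

Compound 4 `N[C@]1(C(=O)O)[C@H]2[C@@H](C[C@H]1OCc1cc(Cl)ccc1Cl)[C@]2(F)C(=O)O` is not yet measured. It differs from compound 2 in one place: chloro in place of hydrogen on an aromatic carbon. The new chloro sits on an aromatic carbon of a six-membered aromatic ring of carbon only, ortho to a large group and para to a chloro group, so the 3-chlorophenyl becomes a 2,5-dichlorophenyl.

Within the data shown here, no measured step adds a chloro to this ring; the step from compound 2 to compound 3 shows only that changing the substituent on this ring moved the number modestly. A second chloro is a smaller change than a phenoxy, so for compound 4 the expected step is a 1.4-fold higher number from compound 2 to compound 4 (0.14 log units; within the scatter), not clearly beyond the scatter. Compound 4 is therefore estimated at 4.5 nM, with a range from 1.8 nM to 12 nM.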

Compound 4, inhibition constant: 11.8 nM
Compound 4: middle estimate off by 2.6-fold (0.42 log units), on the low side, and the stated range covers the measured number.
By their numbers in this assay, from the lowest: compound 2; then compounds 1, 3 and 4 (each within the scatter of the next).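

Turning the 3-chlorophenyl of compound 2 into the 2,5-dichlorophenyl of compound 4 gives a 3.6-fold higher number from compound 2 to compound 4 (0.56 log units; beyond the scatter) in this assay, so this ring position, which carries only hydrogen in compound 2, does not accept a chloro without a measurable loss of binding. The earlier step, a 2.2-fold higher number from compound 2 to compound 3 (0.34 log units; beyond the scatter), involved swapping one substituent for another, whereas this one shows that adding a single chlorine atom at a new place on the ring, ortho to a large group and para to a chloro group, also weakens binding beyond the scatter. Both single-change steps on this ring now raise the number from compound 2, with no step going against that, but the data offer no explanation for the effect of this new chloro.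

A fluoro, a methyl or a methoxy at the same place would show whether the loss is specific to chloro or appears with other groups there. A ring carrying the new chloro alone, without the original chloro, would show whether the new chloro has the same effect on its own.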